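Rearranging the dichlorophenyl group on a carbonyl carbon

The source may report more compounds than this note shows. Statements on the series, on what has been measured and on what is new or still open speak of the compounds shown alone.

Compound 1 `O=C(Nc1ccc2nc(NC(=O)C3CCCCC3)sc2c1)c1ccccc1F` gives 0.14 ug/mL as a measured value
Compound 2 `O=C(Nc1ccc2nc(NC(=O)C3CCCCC3)sc2c1)c1cccc(F)c1` gives 0.64 ug/mL as a measured value
Compound 3 `O=C(Nc1ccc2nc(NC(=O)C3CCCCC3)sc2c1)c1ccc(Cl)cc1Cl` gives > 4 ug/mL as a limit

In a functional assay on WI-38 VA13 cells (Homo sapiens) for cytotoxicity (a lower number here means that less compound is needed, a higher number that more compound is needed for the effect), compound 3 stands at > 4 ug/mL as a limit of the assay and not a number. Compound 4 `O=C(Nc1ccc2nc(NC(=O)C3CCCCC3)sc2c1)c1c(Cl)cccc1Cl` carries 2,6-dichlorophenyl in place of 2,4-dichlorophenyl on a carbonyl carbon and shares the rest of its structure with compound 3. Going by the values given here, no measured compound carries 2,6-dichlorophenyl, so the evidence is indirect. The widest measured step at this place is an at least 28-fold higher number from compound 1 to compound 3 (1.45 log units; beyond the scatter) and the next is an at least 6.2-fold higher number from compound 2 to compound 3 (0.79 log units; beyond the scatter) in the same direction. The step between the two fluorophenyl compounds is a 4.6-fold higher number from compound 1 to compound 2 (0.66 log units; beyond the scatter) and shows that moving one halogen alone shifted the number in this small set. A modest step to a lower number is therefore expected in this assay even though compound 3 offers only a limit as a starting point. The expected change is an at least 2.6-fold lower number from compound 3 to compound 4 (0.42 log units; beyond the scatter) as an estimate. For compound 4 the estimated value is 1.5 ug/mL (expected range 0.3 ug/mL to 6 ug/mL)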

Compound 4, half-maximal effective concentration: 0.015 ug/mL
For compound 4 the middle estimate is 100-fold (2.00 log units) above the measured one; measured number below the stated range.
By their numbers in this assay, from the lowest: compound 4; then compound 1; then compound 2. At a limit, above all of these: compound 3.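

In this assay, this place on the carbonyl carbon proves far more sensitive than the fluorophenyl pair suggested, since the same atoms joined differently give an at least 260-fold lower number from compound 3 to compound 4 (2.42 log units; beyond the scatter). Compound 3, the starting point of that step, stands at a limit and not a number: the limit of > 4 ug/mL in this assay, at which 1 of the 4 values shown sits.

Compound 4 also falls below both fluorophenyl compounds, with a 43-fold lower number from compound 2 to compound 4 (1.63 log units; beyond the scatter) and a 9.3-fold lower number from compound 1 to compound 4 (0.97 log units; beyond the scatter), so a dichlorophenyl group does not by itself go with a higher number, and 2,6-dichlorophenyl gives the lowest number of the four.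

The compounds shown leave open whether the drop depends on chlorine or on the arrangement of the two groups in 2,6-dichlorophenyl, a question that 2,6-difluorophenyl or 2,6-dimethylphenyl would address. They also leave open whether 2,6-dichlorophenyl has the same effect on a different core or in other cells.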